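The source may hold more compounds than are shown below. What is called first, only, known or untested is meant among the compounds shown, and "the series" means these compounds.

In a functional assay on NCI-H1299 cells (Homo sapiens) for antiproliferative activity, read by XTT assay, with a stated time of 72 h (on this read-out higher numbers stand for weaker inhibition and lower numbers for stronger inhibition), compound 2 `COc1ccc(-c2cc3ccccc3nc2/C=C/C(=O)c2ccc(N)cc2)cc1` gives 6510 nM, the lowest of the two numbers seen so far, while compound 1 `COc1ccc(-c2cc3ccccc3nc2/C=C/C(=O)c2ccc(O)cc2)cc1` gives 8970 nM. Going by the values given here, the only measured step, a 1.4-fold lower number from compound 1 to compound 2 (0.14 log units; within the scatter), stayed within the scatter. Compound 3 `COc1ccc(-c2cc3ccccc3nc2/C=C/C(=O)c2ccc([N+](=O)[O-])cc2)cc1` takes this further: nitro in place of amino on an aromatic carbon. Among the compounds with values here, no measured step involves a nitro group, so the expectation rests on the closeness of compound 1 and compound 2 alone. The step from compound 2 to compound 3 is therefore expected to be small, a 1.1-fold higher number from compound 2 to compound 3 (0.03 log units; within the scatter), with no direction beyond the scatter. Compound 3 is estimated at 7000 nM, between 2500 nM and 20000 nM.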

Compound 3, half-maximal inhibitory concentration: 770 nM
Estimate against measurement, compound 3: 9.1-fold (0.96 log units) above; the whole stated range lies above it.
By their numbers in this assay, from the lowest: compound 3; then compounds 2 and 1 (each within the scatter of the next).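

In this assay nitro on this aromatic carbon gives an 8.5-fold lower number from compound 2 to compound 3 (0.93 log units; beyond the scatter) and a 12-fold lower number from compound 1 to compound 3 (1.07 log units; beyond the scatter) and so shows that the place para to a large group is not indifferent, as hydroxy and amino alone had suggested. The group standing here can therefore move the number well beyond the scatter. Nothing measured here accounts for this change. Whether the drop belongs to nitro alone stays open: the compounds shown hold no nitrile, trifluoromethyl or carboxylic acid at this place. They also leave open whether nitro would do the same elsewhere on this ring.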